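The source may report more compounds than this note shows. Statements on the series, on what has been measured and on what is new or still open speak of the compounds shown alone.

Working notes on the series.

The shared core is kept throughout; the three measured compounds are compound 1 `Cc1ccc(-c2cnc(C(=O)CCCCCCc3ccccc3)o2)nc1`, compound 2 `COc1ccnc(-c2cnc(C(=O)CCCCCCc3ccccc3)o2)c1` and compound 3 `NC(=O)c1cccc(-c2cnc(C(=O)CCCCCCc3ccccc3)o2)n1`. In an assay (Rattus norvegicus) for inhibition of Fatty-acid amide hydrolase 1 (Homo sapiens) (on this read-out lower numbers stand for stronger inhibition and higher numbers for weaker inhibition), compound 1 gives 2.8 nM. In this assay compound 2 gives 0.8 nM. In this assay compound 3 gives 1 nM. Compound 3 holds the second highest of the three numbers; its nearest neighbour is compound 2, the distance being a 1.3-fold higher number from compound 2 to compound 3 (0.10 log units; within the scatter), and its furthest is compound 1, seen as a 2.8-fold lower number from compound 1 to compound 3 (0.45 log units; beyond the scatter). The third measured step is a 3.5-fold lower number from compound 1 to compound 2 (0.54 log units; beyond the scatter). All three steps swap one pyridin-2-yl group for another and move the number modestly or not beyond the scatter.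

Compound 4 `CNC(=O)c1cnc(C(=O)CCCCCCc2ccccc2)o1` is not yet measured. The change from compound 3 is methylcarbamoyl in place of 6-carbamoylpyridin-2-yl on an aromatic carbon. Going by the values given here, no measured step bears on this change: every step so far keeps a six-membered aromatic ring at that position, and none removes it. The measured steps therefore give no guide to the size or direction of the step in this assay, and the expectation rests on the fact that the whole ring, with its donor and acceptors, is exchanged for a far smaller group. The number for compound 4 is expected to rise, with a wide range, estimated at 20 nM between 3 nM and 150 nM. That expectation corresponds to a step of a 20-fold higher number from compound 3 to compound 4 (1.30 log units; beyond the scatter).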

Compound 4, inhibition constant: 7 nM
Estimate against measurement, compound 4: 2.9-fold (0.46 log units) above, within the range that was stated.
By their numbers in this assay, from the lowest: compounds 2 and 3 (each within the scatter of the next); then compound 1; then compound 4.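

In this assay the aromatic carbon next to the ring oxygen tolerates complete loss of the six-membered aromatic ring, but at a cost: methylcarbamoyl in place of 6-carbamoylpyridin-2-yl gives a 7.0-fold higher number from compound 3 to compound 4 (0.85 log units; beyond the scatter) and in place of 4-methoxypyridin-2-yl gives an 8.8-fold higher number from compound 2 to compound 4 (0.94 log units; beyond the scatter), both larger than any step among the pyridin-2-yl compounds. In place of 5-methylpyridin-2-yl the same group gives only a 2.5-fold higher number from compound 1 to compound 4 (0.40 log units; beyond the scatter), so the size of the change depends on which pyridin-2-yl group leaves, and a low number does not require a ring at this position, since compound 4 still gives 7 nM in this read-out. No measurement at hand accounts for any of these steps.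

The compounds shown do not separate the loss of the ring from the particular group that enters, so it stays open how a primary carbamoyl, a carboxylic acid, a nitrile or a longer alkyl amide would stand on this carbon. Also open, going by these compounds, is what an unsubstituted pyridin-2-yl or a phenyl would give here, which would show how much of the low numbers of compound 2 and compound 3 belongs to the ring itself and how much to its substituents.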